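Working notes: 4-methylbenzyl to butyl on compound 2

The source may hold more compounds than are shown below. What is called first, only, known or untested is meant among the compounds shown, and "the series" means these compounds.

Three members of the series have numbers in an assay on isolated protein for inhibition of aldehyde dehydrogenase 1A1 (Homo sapiens), read by spectrophotometry, tested at 10 uM; on this read-out higher numbers stand for more inhibition at the one concentration tested (going by the name of the read-out) and lower numbers for less inhibition. Compound 1 `Cc1cccc(Cn2c(OC3CCN(C(=O)c4ccco4)CC3)nc3ccccc32)c1` gives 68.3%. Compound 2 `Cc1ccc(Cn2c(CN3CCN(C(=O)C4CC4)CC3)nc3ccccc32)cc1` gives 51.5%. Compound 3 `Cc1cccc(Cn2c(CN3CCN(C(=O)c4ccc(C#N)cc4)CC3)nc3ccccc32)c1` gives 20.8%. On these three numbers compound 2 stands second highest: compound 1 lies above it by a gap beyond the usual scatter, and compound 3 lies below it by a larger gap, also beyond the scatter. Among the compounds with values here, no two measured compounds differ in one place only, so no single-step change can be read off the measured set.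

Compound 4 `CCCCn1c(CN2CCN(C(=O)C3CC3)CC2)nc2ccccc21` is not yet measured in this assay. It differs from compound 2 in one place: propyl in place of 4-methylphenyl on a saturated chain carbon bound to an aromatic nitrogen. A group with one six-membered aromatic ring of carbon only leaves and a chain with no ring enters, on the saturated chain carbon bound to the aromatic nitrogen. Within the data shown here, no measured pair shows what this exchange does, so the expectation rests on the number of compound 2 alone and is held loosely. The expected step is a number 16.5 percentage points lower from compound 2 to compound 4 (beyond the scatter), a loss reaching beyond the scatter. For compound 4 in this assay the estimate is 35%, with a range from 15% to 55%.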

Compound 4, a percentage reported as inhibition, at one concentration (the size of the read-out at that concentration, not a potency): 18.2%
For compound 4 the middle estimate is 16.8 percentage points above the measured one; low and high end bracket the measured number.
By their numbers in this assay, from the lowest: compounds 4 and 3 (each within the scatter of the next); then compound 2; then compound 1.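

In this assay, within the data shown here, the exchange of 4-methylbenzyl for butyl gives the first single-place comparison: a number 33.3 percentage points lower from compound 2 to compound 4 (beyond the scatter) with the rest of the structure held fixed. Among these compounds, the group on the saturated chain carbon bound to the aromatic nitrogen therefore matters for this read-out, at least in this one structural setting, which the earlier compounds could not show. The exchange removes one six-membered aromatic ring of carbon only and goes from 7 heavy atoms to 3, while the hydrogen-bond donor and acceptor counts and the net charge stay unchanged, and no measurement at hand bears on why the step has this size.

The ring and the atom count change together here, so the compounds shown do not separate the two: unsubstituted benzyl, cyclohexylmethyl and a longer chain such as hexyl would each bear on that question. Also open, on these data alone, is whether the step carries over to other groups on the remainder of the molecule, such as the furan-2-carbonyl amide of compound 1.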